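A few compounds are considered here, and "the series" means these few. Any claim that something is new, unique, unknown or untested is made for them only; others in the source may bear on it.

Working notes on the series in a functional assay on A549 cells (Homo sapiens) for antiproliferative activity, read by MTT assay, with a stated time of 48 h; on this read-out higher numbers stand for weaker inhibition and lower numbers for stronger inhibition.

Within the data shown here, compound 1 `Cc1cc(C)cc(-n2nncc2CN2C(=O)C3(C(C#N)=C(N)Oc4c3c3nc5ccccc5nc3c3ccccc43)c3ccccc32)c1` is the first member of the set. In this assay compound 1 gives only a limit, > 50000 nM, and no number. Compound 2 `Cc1ccc(-n2nncc2CN2C(=O)C3(C(C#N)=C(N)Oc4c3c3nc5ccccc5nc3c3ccccc43)c3ccccc32)cc1Cl` differs from it by a 3-chloro-4-methylphenyl in place of a 3,5-dimethylphenyl on an aromatic nitrogen; in this assay compound 2 likewise gives only a limit, > 50000 nM. The step that the two limits leave unreadable from compound 1 to compound 2 therefore cannot be read, since both ends are limits. Compound 3 `COc1ccc(-n2nncc2CN2C(=O)C3(C(C#N)=C(N)Oc4c(N)cc5nc6ccccc6nc5c43)c3ccccc32)cc1` carries a 4-methoxyphenyl on the same aromatic nitrogen and an amino group on the shared core. In this assay compound 3 also gives only a limit, > 50000 nM. Where compound 3 stands is thus fixed only as a limit, and the same holds for the other two values shown, as summed up by the limit of > 50000 nM in this assay, at which 3 of the 3 values shown sit.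

Compound 4 `Cc1cc(C)c(-n2nncc2CN2C(=O)C3(C(C#N)=C(N)Oc4c(N)cc5nc6ccccc6nc5c43)c3ccccc32)c(C)c1` is not yet measured. It differs from compound 3 as follows: 2,4,6-trimethylphenyl in place of 4-methoxyphenyl on an aromatic nitrogen. Among the measured compounds shown here, no measured step in the set gives a readable size, and the one step that exists, the step from compound 1 to compound 2, is unreadable between two limits, so no direction beyond the scatter can be expected for a step that the limit leaves unreadable from compound 3 to compound 4. Compound 4 is therefore expected to give again a limit in this assay, estimated at 80000 nM with a range from 30000 nM to 300000 nM.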

Compound 4, half-maximal inhibitory concentration: 12700 nM
The estimate for compound 4 lay 6.3-fold (0.80 log units) above the measured number, outside the stated range (below it).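

In this assay, among these compounds, the group on the aromatic nitrogen of the five-membered ring can move the read-out: 2,4,6-trimethylphenyl in place of 4-methoxyphenyl gives an at least 3.9-fold lower number from compound 3 to compound 4 (0.59 log units; beyond the scatter), the first readable step in the set. Compound 1, compound 2 and compound 3 each stay at a limit of the assay and give no number: the limit of > 50000 nM in this assay, at which 3 of the 4 values shown sit. The size of the new step is only a floor, as one of its ends is a limit; the other step in the set lies between two limits and cannot be read.

The compounds shown leave open whether all three methyl groups of the 2,4,6-trimethylphenyl are needed, and what a plain phenyl, a 2,6-dimethylphenyl or a phenyl carrying a carboxylic acid would give at this position. They also leave open whether the step depends on the amino group on the shared core, as no pair shown tests the 2,4,6-trimethylphenyl on the core of compound 1.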